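Little Change Expected from a Longer Urea Side Chain

The source may report more compounds than this note shows. Statements on the series, on what has been measured and on what is new or still open speak of the compounds shown alone.

Values in a functional assay on A549 cells (Homo sapiens) for cytotoxicity, read by MTT assay, with a stated time of 72 h; on this read-out lower numbers stand for stronger inhibition and higher numbers for weaker inhibition:
Compound 1 `COc1ncc(-c2ccc3nc(NC(=O)NC4CC4)nn3c2)cc1NS(=O)(=O)c1ccc(F)cc1`: 210 nM
Compound 2 `CCCNC(=O)Nc1nc2ccc(-c3cnc(OC)c(NS(=O)(=O)c4ccc(F)cc4)c3)cn2n1`: 220 nM

In this assay, for the measured compounds named here, compound 2 stands at 220 nM, level with the only other measured compound. Compound 3 `COc1ncc(-c2ccc3nc(NC(=O)NCCN4CCN(C)CC4)nn3c2)cc1NS(=O)(=O)c1ccc(F)cc1` has not yet been measured. It differs from compound 2 by 4-methylpiperazin-1-yl in place of methyl on a saturated chain carbon, two bonds along the chain from an amide-type nitrogen, so a 2-(4-methylpiperazin-1-yl)ethyl group takes the place of propyl. Going by the values given here, one measured step bears on this site: a 1.0-fold higher number from compound 1 to compound 2 (0.02 log units; within the scatter). Among the compounds with values here, that step exchanged only propyl and cyclopropyl on the amide-type nitrogen, and no measured compound carries a group like the entering one. The evidence therefore gives no direction, and no shift beyond the scatter is expected, though the uncertainty is wide. The expected change is a 1.2-fold higher number from compound 2 to compound 3 (0.07 log units; within the scatter). For compound 3 the estimated value is 260 nM, with an expected range from 90 nM to 800 nM.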

Compound 3, half-maximal inhibitory concentration: 1050 nM
The estimate for compound 3 lay 4.0-fold (0.61 log units) below the measured number; measured number above the stated range.
By their numbers in this assay, from the lowest: compounds 1 and 2 (each within the scatter of the next); then compound 3.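

In this assay the urea side chain proved able to move the number, which the earlier pair could not show, as propyl and cyclopropyl on the amide-type nitrogen stand within the scatter of each other. Putting 4-methylpiperazin-1-yl in place of methyl on the saturated chain carbon gives a 4.8-fold higher number from compound 2 to compound 3 (0.68 log units; beyond the scatter), a weaker result, and the comparison with the cyclopropyl compound agrees, with a 5.0-fold higher number from compound 1 to compound 3 (0.70 log units; beyond the scatter), so this larger ring-bearing side chain is poorer than either small group. Nothing on hand accounts for this step.

The compounds shown cannot separate the part played by the ring from that of its nitrogen atoms; a 2-(morpholin-4-yl)ethyl group, a 2-(dimethylamino)ethyl group or a plain pentyl chain would bear on that. From the compounds shown here alone, how the length of the link counts also stays open, and a 3-(4-methylpiperazin-1-yl)propyl group would test it.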